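The source may report more compounds than this note shows. Statements on the series, on what has been measured and on what is new or still open speak of the compounds shown alone.

In an ADME assay on microsomes from liver (Rattus norvegicus) for metabolic stability, read by LC-MS, using NADPH, with stated times of 10 min and 60 min (on this read-out higher numbers stand for a longer-lived compound and lower numbers for a shorter-lived compound), the measured compounds give these values
compound 1 `CCc1nc(CN(C)C2CCCc3cccnc32)cc(N2CCN(C)CC2)n1` gives 0.0198 h
compound 2 `Cc1nc(CN(C)[C@H]2CCCc3cccnc32)cc(N2CCN(C)[C@@H](C)C2)n1` gives 0.0267 h

Compound 2 at 0.0267 h stands within the usual scatter of compound 1 on these two numbers. Compound 3 `Cc1nc(CN(C)[C@H]2CCCc3cccnc32)cc(N2CCN3CCC[C@H]3C2)n1` has not been measured, and its change from compound 2 is a group of 9 heavy atoms (7 carbon, 2 nitrogen; one five-membered non-aromatic ring with 1 hetero atom, one six-membered non-aromatic ring with 2 hetero atoms) in place of a group of 8 heavy atoms (6 carbon, 2 nitrogen; one six-membered non-aromatic ring with 2 hetero atoms), on an aromatic carbon on the shared core. Among the measured compounds shown here, no measured pair shows a step of this kind, so no step beyond the scatter is expected in this assay and no direction is favoured. The estimated step of a 1.1-fold higher number from compound 2 to compound 3 (0.05 log units; within the scatter) is expected to stay inside that scatter. For compound 3 the estimate is 0.03 h with an expected range from 0.012 h to 0.07 h for repeated measurements.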

Compound 3, half-life: < 0.0167 h
Compound 3: only a limit was reported (the forecaster's own chance of this, stated with the estimate: 10%); middle value at least 1.7-fold (0.25 log units) from the limit.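

In this assay compound 3 gives < 0.0167 h, which is a limit and not a number. Putting the group with a five-membered and a six-membered non-aromatic ring in place of 3,4-dimethylpiperazin-1-yl at this position gives an at least 1.5-fold lower number from compound 2 to compound 3 (0.20 log units; that floor lies within the scatter), so the change has a floor but no fixed size. The reading of compound 3 is set by the assay: the limit of < 0.0167 h in this assay, at which 1 of the 3 values shown sits.

On these data alone, the true size of this step stays open. So does the half-life with a morpholine or an open-chain amine on this aromatic carbon.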